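Trioxolane Amides: From Piperazine to Aminopiperidine

The source may report more compounds than this note shows. Statements on the series, on what has been measured and on what is new or still open speak of the compounds shown alone.

Compound 1 `NC(=O)CNC(=O)C[C@H]1CC[C@]2(CC1)OO[C@]1(O2)C2CC3CC(C2)CC1C3` and compound 2 `O=C(C[C@H]1CC[C@]2(CC1)OO[C@]1(O2)C2CC3CC(C2)CC1C3)N1CCNCC1` share the same core and differ only in the group on the carbonyl carbon. In an ADME assay on microsomes from liver (Mus musculus) for metabolic stability (on this read-out lower numbers stand for slow clearance and higher numbers for fast clearance), compound 1 gives 5.6 uL/min; in this assay compound 2 gives 14.4 uL/min. For the measured compounds named here, the step of a 2.6-fold higher number from compound 1 to compound 2 (0.41 log units; beyond the scatter) is the only measured step in the set, and it leaves compound 2 with the higher of the two measured numbers.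

Compound 3 `NC1CCN(C(=O)C[C@H]2CC[C@]3(CC2)OO[C@]2(O3)C3CC4CC(C3)CC2C4)CC1` is not yet measured. It differs from compound 2 in one place: 4-aminopiperidin-1-yl in place of piperazin-1-yl on a carbonyl carbon. Going by the values given here, the only step that bears on it is a 2.6-fold higher number from compound 1 to compound 2 (0.41 log units; beyond the scatter), which also changed the group on the carbonyl carbon, but from a (carbamoylmethyl)amino group rather than between two cyclic amines, so it is an indirect guide at best. Both the group that leaves and the group that enters keep one hydrogen-bond donor and one acceptor. The step of a 1.0-fold lower number from compound 2 to compound 3 (0.01 log units; within the scatter) is therefore expected to stay within the scatter, with no clear direction. Compound 3 is estimated at 14 uL/min in this assay, with a range from 7 uL/min to 28 uL/min.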

Compound 3, intrinsic clearance in a liver preparation (reported as CLH), per the amount of preparation that the assay uses: 2.5 uL/min
Compound 3: middle estimate off by 5.6-fold (0.75 log units), on the high side, and the stated range ends above it.
By their numbers in this assay, from the lowest: compound 3; then compound 1; then compound 2.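

Within this assay, the exchange of one cyclic amine for another on a carbonyl carbon was not a neutral change: piperazin-1-yl and 4-aminopiperidin-1-yl have the same hydrogen-bond donor and acceptor counts and no net charge, yet the change gives a 5.8-fold lower number from compound 2 to compound 3 (0.76 log units; beyond the scatter). Those shared counts therefore do not fix the clearance number at this place, and neither does the presence of a six-membered ring, as a 2.2-fold lower number from compound 1 to compound 3 (0.35 log units; beyond the scatter) puts 4-aminopiperidin-1-yl below (carbamoylmethyl)amino, while piperazin-1-yl stands above it. No supporting data are available to account for this separation of the two cyclic amines.

The compounds shown leave open whether the lower number depends on the free amino group of 4-aminopiperidin-1-yl or on the piperidine ring that carries it, a question that 4-hydroxypiperidin-1-yl or unsubstituted piperidin-1-yl on the same carbonyl carbon would address. They also leave open whether the number is sensitive to the distance of that amino group from the ring, as 4-(aminomethyl)piperidin-1-yl, with its longer chain, would show.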